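Carboxypyridinyl in place of fluoropyridinyl on the aryl ring

The source may hold more compounds than are shown below. What is called first, only, known or untested is meant among the compounds shown, and "the series" means these compounds.

Within the data shown here, compound 2 `CCC(C)(C)Cc1c[nH]c(CCc2ccc(-c3ccc(F)cn3)cc2)n1` gives 66 nM in a functional assay on HEK293 cells for agonist activity at Bombesin receptor subtype-3 (Homo sapiens), read by luminescence and calcium flux, with a stated time of 10 min (on this read-out higher numbers stand for an effect only at larger amounts of compound and lower numbers for an effect already at smaller amounts), the lowest of the two numbers so far; compound 1 `CCC(C)(C)Cc1c[nH]c(CCc2ccc(-c3cnccn3)cc2)n1` gives 431 nM, and the step of a 6.5-fold lower number from compound 1 to compound 2 (0.81 log units; beyond the scatter) is the only measured one. Compound 3 `CCC(C)(C)Cc1c[nH]c(CCc2ccc(-c3cccnc3C(=O)O)cc2)n1` carries 2-carboxypyridin-3-yl in place of 5-fluoropyridin-2-yl on an aromatic carbon. Among the measured compounds shown here, the measured step concerns an exchange of one six-membered aromatic ring for another and bears only loosely on the present change; no measured step covers entry of a carboxylic acid. A step beyond the scatter toward a higher number is expected, an 11-fold higher number from compound 2 to compound 3 (1.03 log units; beyond the scatter). Compound 3 is estimated at 700 nM, with a range of 150 nM to 3500 nM.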

Compound 3, half-maximal effective concentration: 1260 nM
Estimate against measurement, compound 3: 1.8-fold (0.26 log units) below, within the range that was stated.
By their numbers in this assay, from the lowest: compound 2; then compound 1; then compound 3.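

With 2-carboxypyridin-3-yl on the aromatic carbon para to a large group, the number in this assay rises well beyond the scatter: a 19-fold higher number from compound 2 to compound 3 (1.28 log units; beyond the scatter). The rise also holds against the pyrazin-2-yl group, a 2.9-fold higher number from compound 1 to compound 3 (0.47 log units; beyond the scatter), so this position tolerates the group carrying a hydrogen-bond donor less well than either earlier ring. No available evidence accounts for this rise.

Open, from the compounds shown here alone, is whether the carboxylic acid or the different ring attachment carries the step. A methyl ester or a primary amide in place of the carboxylic acid would test the first of these.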